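The source may hold more compounds than are shown below. What is called first, only, known or untested is meant among the compounds shown, and "the series" means these compounds.

Compound 1 `COc1cc2ncnc(N3CCc4ccccc43)c2cc1NC(=O)C=C(C)C` sits second highest of the three numbers in a functional assay on MCF7 cells (Homo sapiens) for antiproliferative activity, read by MTT assay, with a stated time of 72 h (a higher number here means a weaker inhibitor, a lower number a stronger inhibitor), where compound 1 gives 6390 nM. Compound 2 `CC(C)=CC(=O)Nc1cc2c(N3CCc4ccccc43)ncnc2cc1O[C@@H]1CCOC1` gives 15700 nM, and compound 3 `CCC/C=C/C(=O)Nc1cc2c(N3CCCc4ccccc43)ncnc2cc1OC` gives 1210 nM. Compound 4 `COc1cc2ncnc(N3CCc4ccccc43)c2cc1NC(=O)/C=C/CN1CCN(C)CC1` differs from compound 1 as follows: 3-(4-methylpiperazin-1-yl)prop-1-en-1-yl in place of 2-methylprop-1-en-1-yl on a carbonyl carbon. Going by the values given here, the only single-point step seen, a 2.5-fold higher number from compound 1 to compound 2 (0.39 log units; beyond the scatter), concerns the oxygen substituent and not the acyl group, so it does not bear on this change. Compound 3, which differs from compound 1 at two places, shows a lower number than compound 1 but offers no clean guide. The step of a 2.6-fold lower number from compound 1 to compound 4 (0.41 log units; beyond the scatter) is therefore an expectation of a modest gain with wide uncertainty. For compound 4 the expected value in this assay is 2500 nM, within 700 nM to 9000 nM.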

Compound 4, half-maximal inhibitory concentration: 6430 nM
Compound 4: the middle estimate sits 2.6-fold (0.41 log units) below what was measured; low and high end bracket the measured number.
By their numbers in this assay, from the lowest: compound 3; then compounds 1 and 4 (each within the scatter of the next); then compound 2.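

With 3-(4-methylpiperazin-1-yl)prop-1-en-1-yl in place of 2-methylprop-1-en-1-yl on the carbonyl carbon, the reading in this assay is a 1.0-fold higher number from compound 1 to compound 4 (0.00 log units; within the scatter) for this change. Going by these compounds alone, the position thus takes the larger group, with its six-membered ring and two hydrogen-bond acceptors, with no change beyond the scatter, whereas the only earlier single-place step concerned the oxygen substituent. No available evidence bears on this result. As far as these compounds go, whether a morpholine or dimethylamino group on the same propenyl chain would read alike stays open, as does the effect of the methylpiperazine group alongside the oxolan-3-yl group.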